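A few compounds are considered here, and "the series" means these few. Any claim that something is new, unique, unknown or untested is made for them only; others in the source may bear on it.

Working notes on the series, read in a functional assay on HL-60 cells (Homo sapiens) for inhibition, read by CCK-8 assay, with a stated time of 48 h, tested at 20 uM (a higher number here means more inhibition of growth at the concentration tested, a lower number less inhibition of growth), at a single concentration. Within the data shown here, compound 1 (`COc1ccc(Cc2nnc(NC(=O)/C(C#N)=C/c3ccccc3OS(=O)(=O)c3ccccc3[N+](=O)[O-])s2)cc1`) gives 25% and compound 2 (`COc1ccc(Cc2nnc(NC(=O)/C(C#N)=C/c3ccccc3OS(=O)(=O)c3ccc(Cl)cc3)s2)cc1`) gives 20% in this assay as the only two numbers so far. These two lie within the scatter of each other, so compound 1 has no separate standing in the series.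

Compound 3 (`N#C/C(=C\c1ccccc1OS(=O)(=O)c1ccccc1[N+](=O)[O-])C(=O)Nc1nnc(Cc2ccc(Cl)cc2)s1`) keeps the core of compound 1 and changes one group, 4-methoxybenzyl to 4-chlorobenzyl, with chloro in place of methoxy on an aromatic carbon.

Among the measured compounds shown here, the one measured step (a number 5 percentage points lower from compound 1 to compound 2 (within the scatter)) is 4-chlorophenyl in place of 2-nitrophenyl on a sulfonyl sulfur. It therefore bears only indirectly, as a change elsewhere that stayed within the scatter. For the measured compounds named here, no measured step covers chloro in place of methoxy, so the direction is open and no step beyond the scatter is expected.

The expected step is small (a number 2 percentage points higher from compound 1 to compound 3 (within the scatter)) and is an estimate only.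

Compound 3 is expected at 27% (estimated range 10% to 45%) in this assay once measured.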

Compound 3, percent growth inhibition at one concentration: 19%
Estimate against measurement, compound 3: 8 percentage points above, within the range that was stated.
By their numbers in this assay, from the lowest: compounds 3, 2 and 1 (each within the scatter of the next).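

In this assay, chloro in place of methoxy on an aromatic carbon, para to a large group, gives a number 6 percentage points lower from compound 1 to compound 3 (within the scatter). Among these compounds, this is the first direct reading at this position, and it shows that the exchange of 4-methoxybenzyl for 4-chlorobenzyl, like the earlier change on the sulfonyl sulfur in a number 5 percentage points lower from compound 1 to compound 2 (within the scatter), does not separate from the scatter at this single concentration. No evidence at hand bears on this reading at the position.

From the compounds shown here alone, whether another group on this aromatic carbon, such as an amine, a carboxylic acid or a longer chain, would move the growth inhibition beyond the scatter remains open. Also open, going by these compounds, are how compound 1 and compound 3 would compare over a range of concentrations, and whether chloro at this position would read the same with 4-chlorophenyl in place of 2-nitrophenyl on the sulfonyl sulfur.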